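Neopentyl for methyl on the ring amine of compound 3

This account rests on a few compounds, and the source may have more. Where it says the series, first, only, none or still open, it means among the compounds named here.

Measured so far in an in vitro functional assay on cells for antagonist activity at B1 bradykinin receptor (Homo sapiens), read by luminescence and calcium flux, with a stated time of 2 h; on this read-out higher numbers stand for weaker inhibition and lower numbers for stronger inhibition:
compound 1, `Cc1ccc(S(=O)(=O)N2C=CNC(=O)[C@H]2CC(=O)N[C@@H]2CCCc3ccccc32)cc1`: 3.3 nM
compound 2, `Cc1ccc(S(=O)(=O)N2C=CNC(=O)[C@H]2CC(=O)NC2CCCCC2)cc1`: 990 nM
compound 3, `Cc1ccc(S(=O)(=O)N2C=CNC(=O)[C@H]2CC(=O)N[C@H]2CCN(C)CC2(C)C)cc1`: 0.42 nM

Compound 3 stands lowest of the three numbers in this assay. Its nearest neighbour is compound 1, and the step of a 7.9-fold lower number from compound 1 to compound 3 (0.90 log units; beyond the scatter) is beyond the scatter. Compound 2 lies furthest away, with the step of a 2400-fold lower number from compound 2 to compound 3 (3.37 log units; beyond the scatter) a large one. The third measured step, a 300-fold higher number from compound 1 to compound 2 (2.48 log units; beyond the scatter), is also large. All three steps concern the group on the amide-type nitrogen and nothing else.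

Compound 4, `Cc1ccc(S(=O)(=O)N2C=CNC(=O)[C@H]2CC(=O)N[C@H]2CCN(CC(C)(C)C)CC2(C)C)cc1`, differs from compound 3 at a different site: tert-butyl in place of hydrogen on a saturated chain carbon bound to an amine nitrogen in a ring. Read one bond further out, the change is methyl to neopentyl on the ring amine. Within the data shown here, no measured pair alters this position, so the three steps above give no direct guide to its size or direction. Among the measured compounds shown here, what they show is only that compound 3 already carries the amide-nitrogen group tied to the lowest number seen, and compound 4 keeps that group unchanged.

In the absence of a bearing step, the expectation for compound 4 is a step of a 1.4-fold higher number from compound 3 to compound 4 (0.15 log units; within the scatter), within or near the scatter. Compound 4 is estimated at 0.6 nM, in a range from 0.15 nM to 3 nM.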

Compound 4, half-maximal inhibitory concentration: 1.38 nM
Compound 4: middle estimate off by 2.3-fold (0.36 log units), on the low side; the range from low to high includes it.
By their numbers in this assay, from the lowest: compound 3; then compound 4; then compound 1; then compound 2.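

Among these compounds, compound 4 gives the first reading at this position, the saturated chain carbon bound to an amine nitrogen in a ring, and in this assay the change from methyl to neopentyl gives a 3.3-fold higher number from compound 3 to compound 4 (0.52 log units; beyond the scatter). The amine substituent therefore does register in this read-out, but the step is far smaller than the largest one seen at the amide-type nitrogen, a 300-fold higher number from compound 1 to compound 2 (2.48 log units; beyond the scatter), and adding the four carbons of tert-butyl still leaves compound 4 at 1.38 nM, far from compound 2 at 990 nM. No measurement is available to explain why the number rises with this change.

With only methyl and neopentyl to compare on this amine nitrogen, the compounds shown do not establish whether the number climbs steadily with the size of the chain or whether the step is specific to the tert-butyl end. They leave open how a bare hydrogen on that nitrogen, an intermediate ethyl or isobutyl chain, or a chain ending in a hydroxyl group or a carboxylic acid would read in this assay.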